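Methoxy for trifluoromethyl on a naphthalenol-bearing amidrazone

The source may hold more compounds than are shown below. What is called first, only, known or untested is meant among the compounds shown, and "the series" means these compounds.

In an ADME assay on L6 cells (Rattus norvegicus) for cytotoxicity, read by resazurin assay, with a stated time of 72 h (a higher number here means a weaker inhibitor, a lower number a stronger inhibitor), compound 1 `N/C(CC(O)c1cccc2ccccc12)=N\N=C\c1ccc(C(F)(F)F)cc1` gives 26000 nM, the lower of the two numbers recorded; compound 2 `N/C(CC(O)c1ccc2ccccc2c1)=N\N=C\c1ccc(F)cc1F` gives 93000 nM, a gap that lies beyond the scatter. Compound 3 `COc1ccc(/C=N/N=C(\N)CC(O)c2cccc3ccccc23)cc1` is not yet measured in this assay. It differs from compound 1 in one place: methoxy in place of trifluoromethyl on an aromatic carbon, on an aromatic carbon of a six-membered aromatic ring of carbon only, para to a large group. Going by the values given here, no comparable step is available, so the expectation rests on compound 1 alone. The estimated step of a 1.5-fold higher number from compound 1 to compound 3 (0.19 log units; within the scatter) is a modest rise, near the edge of the scatter. Compound 3 is therefore expected to give about 40000 nM, within 15000 nM to 110000 nM.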

Compound 3, half-maximal inhibitory concentration: 6300 nM
Compound 3: the middle estimate sits 6.3-fold (0.80 log units) above what was measured; measured number below the stated range.
By their numbers in this assay, from the lowest: compound 3; then compound 1; then compound 2.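

In this assay, going by these compounds alone, methoxy in place of trifluoromethyl on an aromatic carbon, para to a large group, gives a 4.1-fold lower number from compound 1 to compound 3 (0.62 log units; beyond the scatter), the first single-place change here. It shows that the number responds to the group at this position, which compounds 1 and 2, differing in more than one place, could not show. Nothing available accounts for the size or direction of this step.

As far as these compounds go, whether the step follows the oxygen of methoxy or the loss of trifluoromethyl stays open, and a methyl, a hydroxyl or an amine on the same carbon would bear on that. From the compounds shown here alone, whether the change carries over to another core also stays open.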